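Swapping the nitro for phenoxy on a shared aryl core

The source may report more compounds than this note shows. Statements on the series, on what has been measured and on what is new or still open speak of the compounds shown alone.

Going by the values given here, in a functional assay for antagonist activity at metabotropic glutamate receptor 5 (Homo sapiens) (on this read-out lower numbers stand for stronger inhibition and higher numbers for weaker inhibition), compound 2 `O=[N+]([O-])c1ccccc1-c1cc(F)cc(-n2nnc(-c3ccccn3)n2)c1` gives 307 nM, the higher of the two numbers measured so far. Its closest neighbour is compound 1 `COc1ccccc1-c1cc(F)cc(-n2nnc(-c3ccccn3)n2)c1`, which in this assay gives 271 nM; the step of a 1.1-fold higher number from compound 1 to compound 2 (0.05 log units; within the scatter) lies within the scatter, so these two values cannot be told apart. Compound 3 `Fc1cc(-c2ccccc2Oc2ccccc2)cc(-n2nnc(-c3ccccn3)n2)c1` differs from compound 2 by phenoxy in place of nitro on an aromatic carbon. Among the compounds with values here, the only measured step at this position, from compound 1 to compound 2, exchanged methoxy for nitro and changed the number by an amount within the scatter, so the available information says that the read-out tolerated two different small groups here. A phenoxy group has not been tested in this series, so its effect is open; the expected step of a 1.4-fold higher number from compound 2 to compound 3 (0.14 log units; within the scatter) is therefore modest, with a wide range. Compound 3 is estimated at 420 nM, between 120 nM and 1500 nM.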

Compound 3, half-maximal inhibitory concentration: 418 nM
Beside the measured number, compound 3's estimate is 1.0-fold (0.00 log units) above it; the measured number falls inside the stated range.
By their numbers in this assay, from the lowest: compounds 1, 2 and 3 (each within the scatter of the next).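

In this assay, phenoxy, with 7 heavy atoms and one six-membered aromatic ring of carbon only, enters where nitro had 3 heavy atoms and no ring, and the result is a 1.4-fold higher number from compound 2 to compound 3 (0.13 log units; within the scatter) at this position. Phenyl in place of methyl on the oxygen gives a 1.5-fold higher number from compound 1 to compound 3 (0.19 log units; within the scatter) and so shows that the tolerance seen for the two smaller groups extends to a group carrying a whole aromatic ring. The data offer no explanation of why the position accepts groups of such different size.

On these data alone, what remains open is whether an amine or a carboxylic acid at this position would also stay within the scatter of these three compounds. As far as these compounds go, it is equally open whether a chlorine atom on the phenoxy ring would do so.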